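Halogen variant of compound 2: expected inhibition

This account rests on a few compounds, and the source may have more. Where it says the series, first, only, none or still open, it means among the compounds named here.

All numbers below come from an assay on isolated protein for inhibition of Amine oxidase [flavin-containing] B (Homo sapiens), read by fluorescence, with a stated time of 15 min; on this read-out lower numbers stand for stronger inhibition and higher numbers for weaker inhibition.
compound 1 `CCOc1ccc2cc(C(=O)/C=C/c3c(/C=C/c4ccc(OC)cc4)cc(OC)cc3OC)c(=O)oc2c1`: 48100 nM
compound 2 `COc1ccc(/C=C/c2cc(OC)cc(OC)c2/C=C/C(=O)c2cc3ccc(Cl)cc3oc2=O)cc1`: 7360 nM
compound 3 `COc1ccc(/C=C/c2cc(OC)cc(OC)c2/C=C/C(=O)c2cc3ccc(OC)cc3oc2=O)cc1`: 4200 nM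

Compound 2 stands second highest of the three numbers. Its nearest neighbour is compound 3, reached by a 1.8-fold lower number from compound 2 to compound 3 (0.24 log units; within the scatter); its furthest is compound 1, from which a 6.5-fold lower number from compound 1 to compound 2 (0.82 log units; beyond the scatter) leads down to compound 2.

Compound 4 `COc1ccc(/C=C/c2cc(OC)cc(OC)c2/C=C/C(=O)c2cc3cc(Br)ccc3oc2=O)cc1` differs from compound 2 by a group of 12 heavy atoms (9 carbon, 2 oxygen, 1 bromine; one six-membered aromatic ring of carbon only, one six-membered aromatic ring with 1 hetero atom) in place of a group of 12 heavy atoms (9 carbon, 2 oxygen, 1 chlorine; one six-membered aromatic ring of carbon only, one six-membered aromatic ring with 1 hetero atom), on a carbonyl carbon. For the measured compounds named here, no measured step covers this exchange of one halogen-bearing group for another. The steps of a 6.5-fold lower number from compound 1 to compound 2 (0.82 log units; beyond the scatter) and an 11-fold lower number from compound 1 to compound 3 (1.06 log units; beyond the scatter) both remove an ethoxy, and a 1.8-fold lower number from compound 2 to compound 3 (0.24 log units; within the scatter) swaps chloro for methoxy without leaving the scatter. Going by the values given here, the only reading the data allow is that the halogen-bearing carrier groups behave alike, so in this assay no step beyond the scatter is expected from compound 2 to compound 4, i.e. a 1.1-fold lower number from compound 2 to compound 4 (0.02 log units; within the scatter) is the estimate. Compound 4 is therefore expected to give about 7000 nM in this assay, with a range from 2500 nM to 20000 nM.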

Compound 4, half-maximal inhibitory concentration: > 60000 nM
Compound 4: no number, only a limit (the forecaster's own chance of this, stated with the estimate: 5%); middle value at least 8.5-fold (0.93 log units) away from the limit.
By their numbers in this assay, from the lowest: compounds 3 and 2 (each within the scatter of the next); then compound 1. At a limit, above all of these: compound 4.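

Compound 4 gives no number in this assay, only a limit: the limit of > 60000 nM in this assay, at which 1 of the 4 values shown sits. Exchanging the chlorine-bearing group on the carbonyl carbon for the bromine-bearing group gives an at least 8.1-fold higher number from compound 2 to compound 4 (0.91 log units; beyond the scatter), so the two halogen-bearing groups are not interchangeable at this place. The earlier exchange of chloro for methoxy, a 1.8-fold lower number from compound 2 to compound 3 (0.24 log units; within the scatter), gave no sign that a change here could matter this much while the halogen stayed on the group.

Still open, on these data alone, are the full size of this step and whether it follows from bromine itself or from where bromine sits on the group, since the two groups differ in that too. Also open, as far as these compounds go, is how a group carrying fluoro, an amine or a carboxylic acid would read at the same place in this assay.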